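Cytotoxicity notes: benzyl substituent change, compound 2 to 3

The compounds below may be only part of what the source reports. "The series", "measured", "known", "first", "only" and "open" are said of these compounds alone.

Measured so far:
compound 1 `Cc1cc(=O)oc2cc(OCC(O)CN3CCC(C(N)=O)CC3)ccc12` — in an ADME assay on A549 cells (Homo sapiens) for cytotoxicity, read by CellTiter-Glo (on this read-out higher numbers stand for lower toxicity in this test and lower numbers for higher toxicity in this test), compound 1 gives > 100000 nM, a limit of the assay rather than a number.
compound 2 `Cc1c(Cc2ccc(Cl)cc2)c(=O)oc2cc(OCC(O)CN3CCC(C(N)=O)CC3)ccc12` — in this assay compound 2 gives 40000 nM.

Compound 2 therefore holds the only number shown in this assay; the one further value is a limit. Within the data shown here, the single measured step, an at least 2.5-fold lower number from compound 1 to compound 2 (0.39 log units; beyond the scatter), puts 4-chlorobenzyl in place of hydrogen on an aromatic carbon; since it starts from the limit of > 100000 nM in this assay, at which 1 of the 2 values shown sits, only its lower bound is known.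

Compound 3 `Cc1c(Cc2ccc(-c3ccccc3C#N)cc2)c(=O)oc2cc(OCC(O)CN3CCC(C(N)=O)CC3)ccc12` differs from compound 2 by 2-cyanophenyl in place of chloro on an aromatic carbon. Among the measured compounds shown here, no measured step alters a group on the benzyl ring itself, so the only step that bears on this change is the one that installed the 4-chlorobenzyl, and it is at least modest in size. On that basis a further lowering of the number, beyond the scatter but modest, is expected: a 1.6-fold lower number from compound 2 to compound 3 (0.20 log units; within the scatter). For compound 3 in this assay the estimate is 25000 nM, with a range of 8000 nM to 80000 nM.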

Compound 3, half-maximal cytotoxic concentration: 33200 nM
For compound 3 the middle estimate is 1.3-fold (0.12 log units) below the measured one, and the stated range covers the measured number.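

In this assay, 2-cyanophenyl in place of chloro gives a 1.2-fold lower number from compound 2 to compound 3 (0.08 log units; within the scatter), so the two compounds cannot be told apart on this read-out. The aromatic carbon para to a large group thus carries either a single chlorine or a group of 8 heavy atoms, with a six-membered aromatic ring and a nitrile, without a change beyond the scatter. Among these compounds, the earlier compounds showed only the effect of installing the 4-chlorobenzyl, a step beyond the scatter; this is the first reading of a change on the benzyl ring itself, and it lies within the scatter.

Whether the nitrile matters apart from the added ring remains open, since plain phenyl is not among the compounds shown, and the same holds for an amine or a carboxylic acid at this position, which could show whether the read-out responds to a change here at all. Compound 1 stands at a limit of the assay, so the full size of the step that installed the 4-chlorobenzyl also stays unknown: the limit of > 100000 nM in this assay, at which 1 of the 3 values shown sits.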